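Compound 4: chloro in place of methyl

The source may report more compounds than this note shows. Statements on the series, on what has been measured and on what is new or still open speak of the compounds shown alone.

Working notes on the shared core, as seen in compound 1 (`CCOC(=O)c1cc(/C=C/c2ccccc2)on1`). In an ADME assay on Vero cells (Chlorocebus sabaeus) for cytotoxicity, with a stated time of 72 h (on this read-out higher numbers stand for weaker inhibition and lower numbers for stronger inhibition), compound 1 stands as "not determined" (no result reported) and offers no result to work from. Compound 2 (`CCOC(=O)c1cc(/C=C/c2cccc(C(F)(F)F)c2)on1`) gives > 128000 nM as its entry, and that is a limit of the assay, not a number. Compound 3 (`CCOC(=O)c1cc(/C=C/c2cccc(C)c2)on1`) gives > 128000 nM as its entry, again a limit of the assay and not a number. Compound 3 therefore has no numeric position in the series, and the whole picture so far is one shared limit (the limit of > 128000 nM in this assay, at which 2 of the 3 values shown sit) with no graded values.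

Compound 4 (`CCOC(=O)c1cc(/C=C/c2cccc(Cl)c2)on1`) differs from compound 3 by a single change (chloro in place of methyl on an aromatic carbon), chloro in place of methyl on an aromatic carbon, meta to a large group. Within the data shown here, the one measured step bearing on it (a step that the two limits leave unreadable from compound 2 to compound 3) is methyl in place of trifluoromethyl on an aromatic carbon and offers neither a size nor a direction, so no step beyond the scatter is expected in this assay for this change. The expected step (a number no higher from compound 3 to compound 4 (the limit leaves the size open)) fits that reading, and a report at the same limit is the likeliest outcome. Compound 4 is estimated at 128000 nM with an expected range from 64000 nM to 200000 nM as a working figure.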

Compound 4, half-maximal inhibitory concentration: > 128000 nM
Compound 4 gave a limit, no number; the forecaster's own chance of this, stated with the estimate: 80%; the middle value sits exactly at the limit.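

In this assay compound 4 gives > 128000 nM as its entry, a limit of the assay and not a number. Among these compounds, no step among compound 2, compound 3 and compound 4 can be read, since all three rest on the same limit: the limit of > 128000 nM in this assay, at which 3 of the 4 values shown sit. The compounds shown leave open whether any change at this aromatic carbon would give a graded value.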